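Dropping the ester from a cinnamamide thiol

This account rests on a few compounds, and the source may have more. Where it says the series, first, only, none or still open, it means among the compounds named here.

Three compounds share a thiol-bearing amide chain. In a functional assay, with a stated time of 30 min, tested at 100 uM (on this read-out lower numbers stand for a weaker effect and higher numbers for a stronger effect at the one concentration tested), compound 1 `Cc1c(C)c2c(c(C)c1O)CCC(C)(C(=O)NCCS)O2` gives 92% and compound 2 `CCOC(=O)C(CS)NC(=O)C1(C)CCc2c(C)c(O)c(C)c(C)c2O1` gives 91%; the step of a number 1 percentage points lower from compound 1 to compound 2 (within the scatter) changes little. Compound 3 `CCOC(=O)C(CS)NC(=O)/C=C/c1ccccc1` gives 42% in this assay, the lowest of the three, clearly apart from both others. Compound 4 `O=C(/C=C/c1ccccc1)NCCS` is compound 3 with hydrogen in place of ethoxycarbonyl on a saturated chain carbon bound to an amide-type nitrogen and a saturated chain carbon. Going by the values given here, the one measured step that bears on this change is the reverse one, where the same ethoxycarbonyl entered at the same place: a number 1 percentage points lower from compound 1 to compound 2 (within the scatter). On that basis the step from compound 3 to compound 4 is expected to stay within the scatter, and the estimate is no change at the digits printed from compound 3 to compound 4 (within the scatter). Compound 4 is therefore expected to give about 42% in this assay, likely between 25% and 60%.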

Compound 4, a percentage reported as activity, at one concentration (the size of the read-out at that concentration, not a potency): 59%
Compound 4: the middle estimate sits 17 percentage points below what was measured; the range from low to high includes it.
By their numbers in this assay, from the lowest: compound 3; then compound 4; then compounds 2 and 1 (each within the scatter of the next).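

On the core of compound 3, removing the ethoxycarbonyl is a real change in this assay, giving a number 17 percentage points higher from compound 3 to compound 4 (beyond the scatter). The effect of this group at this place therefore differs between the two cores, so the near-silent first pair cannot be taken as a general rule: the same change on two cores in this assay, a number 1 percentage points lower (within the scatter) from compound 1 to compound 2 and a number 17 percentage points lower (beyond the scatter) from compound 4 to compound 3, 16 percentage points apart, beyond the scatter of two such steps

Going by these compounds alone, with only two pairs, it remains open how a carboxylic acid or a longer chain at this saturated chain carbon would compare with ethoxycarbonyl and hydrogen. All the compounds shown also keep the thiol, so the effect of a hydroxyl group there remains unknown.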